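Ester variation at the shared lactone core

The source may hold more compounds than are shown below. What is called first, only, known or untested is meant among the compounds shown, and "the series" means these compounds.

Compound 1 `C=C1C(=O)O[C@H]2CC3=C[C@H](C/C(C)=C/[C@@H](OC(=O)CCCCBr)[C@H]12)OC3=O` sits at the limit > 10000 nM of a functional assay on A549 cells (Homo sapiens) for cytotoxicity, read by MTT assay, with a stated time of 48 h; a higher number here means a weaker inhibitor, a lower number a stronger inhibitor. Compound 2 `C=C1C(=O)O[C@H]2CC3=C[C@H](C/C(C)=C/[C@@H](OC(=O)CCCCC)[C@H]12)OC3=O` likewise sits at the limit > 10000 nM. Within the data shown here, compound 3 `C=C1C(=O)O[C@H]2CC3=C[C@H](C/C(C)=C/[C@@H](OC(=O)C45CCC(C)(C(=O)O4)C5(C)C)[C@H]12)OC3=O` gives 3400 nM in this assay, the only number among the three. The values of compound 1 and compound 2 are limits (the limit of > 10000 nM in this assay, at which 2 of the 3 values shown sit). The steps to it are an at least 2.9-fold lower number from compound 1 to compound 3 (0.46 log units; beyond the scatter) and an at least 2.9-fold lower number from compound 2 to compound 3 (0.46 log units; beyond the scatter), both at least modest. Compound 4 `C=C1C(=O)O[C@H]2CC3=C[C@H](C/C(C)=C/[C@@H](OC(=O)/C=C/c4ccncc4)[C@H]12)OC3=O` carries a group of 8 heavy atoms (7 carbon, 1 nitrogen; one six-membered aromatic ring with 1 hetero atom) in place of a group of 11 heavy atoms (9 carbon, 2 oxygen; one five-membered non-aromatic ring of carbon only, one five-membered non-aromatic ring with 1 hetero atom), on a carbonyl carbon. Among the measured compounds shown here, the two measured steps bear on this change only in that the group leaving compound 3 is the one that brought a number below the limit; no step to a pyridinyl ester exists. The number is therefore expected to move up, with a step of a 1.6-fold higher number from compound 3 to compound 4 (0.21 log units; within the scatter) judged likely. Compound 4 is estimated at 5500 nM, within 1500 nM to 20000 nM.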

Compound 4, half-maximal inhibitory concentration: 4000 nM
Compound 4: middle estimate off by 1.4-fold (0.14 log units), on the high side; low and high end bracket the measured number.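

In this assay, a second group at this carbonyl carbon comes in under the limit: 2-(pyridin-4-yl)ethenyl gives an at least 2.5-fold lower number from compound 2 to compound 4 (0.39 log units; beyond the scatter) and an at least 2.5-fold lower number from compound 1 to compound 4 (0.39 log units; beyond the scatter). Both steps start from a limit, not a number: the limit of > 10000 nM in this assay, at which 2 of the 4 values shown sit. The two ring-bearing groups cannot be told apart, with a 1.2-fold higher number from compound 3 to compound 4 (0.07 log units; within the scatter), so here both ring-bearing esters read below the limit and both open-chain esters sit at it.

As far as these compounds go, whether the pyridine nitrogen or the ethenyl link carries the step stays open. A phenyl or piperidine ring in the same place would address this.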